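This account rests on a few compounds, and the source may have more. Where it says the series, first, only, none or still open, it means among the compounds named here.

Measured so far in a functional assay on KB cells (Homo sapiens) for inhibition, read by MTT assay, with a stated time of 24 h, tested at 100 ug/mL; on this read-out higher numbers stand for more inhibition of growth at the one concentration tested and lower numbers for less inhibition of growth:
Compound 1 `O=C(CCCCC(S)CCS)Nc1ccccc1`: 15.8%
Compound 2 `O=C(CCCCC(S)CCS)Nc1ccccc1Cl`: "not active" (no number reported)
Compound 3 `Cc1cccc(NC(=O)CCCCC(S)CCS)c1`: 17.5%

Only compound 1 and compound 3 carry a number in this assay, and these two numbers lie within the scatter of each other. Going by the values given here, compound 2 has no number, so it gives no size of step.

Compound 4 `COc1ccc(NC(=O)CCCCC(S)CCS)cc1` has not yet been measured. Its difference from compound 1 is methoxy in place of hydrogen on an aromatic carbon, which is methoxy in place of hydrogen on an aromatic carbon, para to a large group.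

Among the compounds with values here, the one measured step that bears on this change is a number 1.7 percentage points higher from compound 1 to compound 3 (within the scatter), where methyl replaces hydrogen on an aromatic carbon. Within the data shown here, with only that small step to go on, no change beyond the scatter is expected in this assay. Compound 2, reported as "not active" (no number reported), shows that a change on the ring may not always be so quiet, so the range is kept wide.

The estimated change is a number 1.2 percentage points higher from compound 1 to compound 4 (within the scatter). The expected value for compound 4 is 17%, with an estimated range from 5% to 30%.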

Compound 4, percent growth inhibition at one concentration: 22.2%
Estimate against measurement, compound 4: 5.2 percentage points below, and the stated range covers the measured number.
By their numbers in this assay, from the lowest: compounds 1, 3 and 4 (each within the scatter of the next).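

In this assay, methoxy in place of hydrogen on an aromatic carbon, para to a large group, gives a number 6.4 percentage points higher from compound 1 to compound 4 (within the scatter) and so stays inside the usual spread of repeated measurements. Going by these compounds alone, this is the first group on the ring in this set that brings in an oxygen, and compound 4 still keeps a reported number, as compound 1 does. No measurement of any other kind is at hand to explain this result.

The compounds shown leave open whether an amine or a carboxylic acid at the same place, para to a large group, would give a step beyond the scatter. They also leave open whether a longer chain on that oxygen, such as ethoxy, would keep the number within the scatter of compound 1.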